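A Trimethoxyphenyl Swap Among Closely Grouped Values

The source may report more compounds than this note shows. Statements on the series, on what has been measured and on what is new or still open speak of the compounds shown alone.

In a functional assay on HepG2 cells (Homo sapiens) for cytotoxicity, read by MTT assay, with a stated time of 24 h (a lower number here means a stronger inhibitor, a higher number a weaker inhibitor), compound 1 `O=C1/C(=C/c2ccccc2F)CN(S(=O)(=O)c2ccc(F)cc2)C/C1=C\c1ccccc1F` gives 7220 nM and stands within the scatter of the other two measured compounds. Compound 2 `O=C1/C(=C/c2cccc([N+](=O)[O-])c2)CN(S(=O)(=O)c2ccc(F)cc2)C/C1=C\c1cccc([N+](=O)[O-])c1` gives 8760 nM and compound 3 `CC(=O)Nc1ccc(S(=O)(=O)N2C/C(=C\c3ccccc3F)C(=O)/C(=C/c3ccccc3F)C2)cc1` gives 5840 nM in this same test, so all three values form one close group.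

Compound 4 `COc1cc(/C=C2\CN(S(=O)(=O)c3ccc(F)cc3)C/C(=C\c3ccccc3F)C2=O)cc(OC)c1OC` has not yet been measured. It differs from compound 1 in one place: 3,4,5-trimethoxyphenyl in place of 2-fluorophenyl on a double-bonded chain carbon bound to a double-bonded ring carbon with 3,4,5-trimethoxyphenyl in place of 2-fluorophenyl on a double-bonded chain carbon bound to a double-bonded ring carbon. Among the measured compounds shown here, the only single-place step available, a 1.2-fold lower number from compound 1 to compound 3 (0.09 log units; within the scatter), lies within the scatter, but it concerns a different place and bears on this change only indirectly. For the measured compounds named here, no measured compound carries the entering group. No step beyond the scatter is therefore expected in this assay and no direction can be favoured. The expected step is a 1.1-fold lower number from compound 1 to compound 4 (0.05 log units; within the scatter) and it stays within the scatter. For compound 4 the estimated value is 6500 nM with an expected range of 3000 nM to 14000 nM for repeated measurements.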

Compound 4, half-maximal inhibitory concentration: 7940 nM
The estimate for compound 4 lay 1.2-fold (0.09 log units) below the measured number; the range from low to high includes it.
By their numbers in this assay, from the lowest: compounds 3, 1, 4 and 2 (each within the scatter of the next).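

In this assay, among the compounds shown here, the exchange at this place gives a 1.1-fold higher number from compound 1 to compound 4 (0.04 log units; within the scatter), the first measured step at a double-bonded chain carbon bound to a double-bonded ring carbon. Replacing 2-fluorophenyl, with 7 heavy atoms and no hydrogen-bond acceptors, by 3,4,5-trimethoxyphenyl, with 12 heavy atoms and 3 hydrogen-bond acceptors, therefore leaves the number within the scatter. Nothing available gives a measured reason for this outcome.

From the compounds shown here alone, whether a group of another kind at this place, such as a dimethylamino group or a carboxylic acid, would also stay within the scatter remains open. So does whether 3,4,5-trimethoxyphenyl would behave the same way with acetamido in place of fluoro on the aromatic carbon changed in compound 3.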